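The source may hold more compounds than are shown below. What is called first, only, known or untested is meant among the compounds shown, and "the series" means these compounds.

Of the compounds shown here, three built on one shared core have been tested in an ADME assay on cells (Homo sapiens) for cytotoxicity, read by polymerase chain reaction, with a stated time of 3 days; on this read-out lower numbers stand for higher toxicity in this test and higher numbers for lower toxicity in this test. Compound 1 `CCNc1nc(C)c(-c2nc3ccccc3s2)c(N[C@@H]2C[C@H](CO)[C@@H](O)[C@H]2O)n1` gives 12000 nM. Compound 2 `Cc1nc(NCCNS(C)(=O)=O)nc(N[C@@H]2C[C@H](CO)[C@@H](O)[C@H]2O)c1-c1nc2ccccc2s1` reaches only a limit of the test, > 25000 nM. Compound 3 `Cc1nc(Nc2ccccc2)nc(N[C@@H]2C[C@H](CO)[C@@H](O)[C@H]2O)c1-c1nc2ccccc2s1` likewise stops at a limit, > 25000 nM. Compound 3 therefore sits at the ceiling of the test, as shown by the limit of > 25000 nM in this assay, at which 2 of the 3 values shown sit, where compound 2 also sits. Compound 4 `Cc1nc(Nc2ncco2)nc(N[C@@H]2C[C@H](CO)[C@@H](O)[C@H]2O)c1-c1nc2ccccc2s1` differs from compound 3 by 1,3-oxazol-2-yl in place of phenyl on a nitrogen on an aromatic ring. The nearest measured step is an at least 2.0-fold higher number from compound 1 to compound 3 (0.31 log units; beyond the scatter), while a step that the two limits leave unreadable from compound 2 to compound 3 offers no size. Changes on this nitrogen have so far left the number at the limit, so no step beyond the scatter is expected, a number no higher from compound 3 to compound 4 (the limit leaves the size open). Compound 4 is expected to give about 25000 nM, between 10000 nM and 60000 nM.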

Compound 4, half-maximal cytotoxic concentration: > 25000 nM
Compound 4: a limit, no number; the forecaster's own chance of this, stated with the estimate: 60%; the middle value sits exactly at the limit.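

With the 1,3-oxazol-2-yl group of compound 4, a five-membered aromatic ring with hetero atoms on this nitrogen also ends at a limit in this assay, like the six-membered phenyl ring of compound 3: the limit of > 25000 nM in this assay, at which 3 of the 4 values shown sit. Putting 1,3-oxazol-2-yl in place of ethyl gives an at least 2.0-fold higher number from compound 1 to compound 4 (0.31 log units; beyond the scatter). The steps to compound 4 from compound 2 and compound 3 cannot be read: each joins two limits.

On these data alone, how these three groups rank beyond the limit stays open. So does whether a primary amine or a carboxylic acid on this nitrogen would give a readable number, as ethyl does.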